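Hydroxypropyl for Chloro on a Fused Benzoxazole Core

A few compounds are considered here, and "the series" means these few. Any claim that something is new, unique, unknown or untested is made for them only; others in the source may bear on it.

Compound 1, `CCn1c(CNc2ccccc2)nnc1SCc1nc2cc(Cl)ccc2o1`: 92%
Compound 2, `CCC(=O)c1ccc2nc(CSc3nnc(CNc4ccccc4)n3CC)oc2c1`: 35%

In an ADME assay on blood (Rattus norvegicus) for metabolic stability, with a stated time of 2 h (a higher number here means that more of the compound is left, a lower number that less of the compound is left), compound 1 gives 92%, the highest of the two numbers shown. The nearest number belongs to compound 2, which in this assay gives 35%, a gap that lies beyond the scatter. Among the measured compounds shown here, no step between these two compounds is worked out here, so only their two values can be compared.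

Compound 3, `CCC(O)c1ccc2oc(CSc3nnc(CNc4ccccc4)n3CC)nc2c1`, has not yet been measured in this assay. It differs from compound 1 by 1-hydroxypropyl in place of chloro on an aromatic carbon. Given that compound 2, carrying a three-carbon chain on the same kind of fused core, gives 35%, the step from compound 1 to compound 3 is expected to be downward and beyond the scatter, estimated as a number 37 percentage points lower from compound 1 to compound 3 (beyond the scatter). Compound 3 is therefore expected to give about 55% in this assay, with a likely range from 25% to 85%.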

Compound 3, percent of the compound remaining: 80%
Beside the measured number, compound 3's estimate is 25 percentage points below it; the range from low to high includes it.
By their numbers in this assay, from the lowest: compound 2; then compound 3; then compound 1.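

The first step read at this position comes in this assay, where 1-hydroxypropyl in place of chloro on an aromatic carbon gives a number 12 percentage points lower from compound 1 to compound 3 (beyond the scatter). The step lies beyond the scatter but is modest, so this aromatic carbon accepts a swap from a single chlorine atom to a four-heavy-atom chain carrying a hydrogen-bond donor and acceptor, and compound 3 still gives 80%. Nothing available explains why the number falls by this amount.

Among the compounds shown here, the single step cannot separate the contribution of the three-carbon chain from that of its hydroxyl group. Going by these compounds, whether a hydroxymethyl group, a longer chain or an amine at the same aromatic carbon would stay as close to compound 1 remains open.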